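The compounds below may be only part of what the source reports. "The series", "measured", "known", "first", "only" and "open" are said of these compounds alone.

Working notes on the series.

Compound 2 `COc1ccc(CNc2nc3cc(N)cc(N)c3nc2-c2ccccc2)cc1OC` is the reference point here. In a functional assay on PC-3 cells (Homo sapiens) for inhibition, read by sulforhodamine B assay, with a stated time of 48 h (a lower number here means a stronger inhibitor of growth, a higher number a weaker inhibitor of growth), compound 2 gives 27500 nM, the only number shown in this assay so far. Compound 1 `COc1cc(CNc2nc3cc(N)cc(N)c3nc2-c2ccccc2)cc(OC)c1OC` is reported in this assay only as a limit, < 50200 nM. The step that the limit leaves unreadable from compound 1 to compound 2 is therefore unreadable, because the limit of < 50200 nM in this assay, at which 1 of the 2 values shown sits, fixes only one side of it.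

Compound 3 `COc1ccc(CNc2nc3cc(N)cc(N)c3nc2-c2ccccc2)cc1` differs from compound 2 by hydrogen in place of methoxy on an aromatic carbon. Within the data shown here, the one measured step of the same kind, from compound 1 to compound 2, gives no readable size, so no direction is supported by the numbers in this assay. The expectation for compound 3 is set near compound 2, with a wide range to cover a shift either way; the step of a 1.1-fold higher number from compound 2 to compound 3 (0.04 log units; within the scatter) is thus estimated as within the scatter. Compound 3 is expected at 30000 nM, between 10000 nM and 80000 nM.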

Compound 3, concentration for total growth inhibition: 27500 nM
Beside the measured number, compound 3's estimate is 1.1-fold (0.04 log units) above it; the range from low to high includes it.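

The change from 3,4-dimethoxyphenyl to 4-methoxyphenyl now has a readable size in this assay, and it shows no change at the digits printed from compound 2 to compound 3 (within the scatter). In this one pair, a methoxy at this position, ortho to a methoxy group, gives way to hydrogen with no shift beyond the scatter. The earlier step of the same kind gave no such reading, because one of its two values is a limit: the limit of < 50200 nM in this assay, at which 1 of the 3 values shown sits.

On these data alone, whether a different group at this position, such as a hydroxyl, an amine or a carboxylic acid, would read the same stays open. Also open, as far as these compounds go, is what happens when the methoxy still present in compound 3 gives way to hydrogen, and a single readable pair sets no pattern for the series.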